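The compounds below may be only part of what the source reports. "The series", "measured", "known", "first", "only" and "open" are said of these compounds alone.

Measured in a functional assay on HT-29 cells (Homo sapiens) for inhibition, read by MTT assay, with a stated time of 48 h; a higher number here means a weaker inhibitor, a lower number a stronger inhibitor:
Compound 1 (`COc1ccc(-n2c(SC)nnc2-c2cc(OC)c(OC)c(OC)c2)cc1`) gives > 60000 nM as a limit
Compound 2 (`COc1ccc(-n2c(SCc3ccccc3)nnc2-c2cc(OC)c(OC)c(OC)c2)cc1`) gives > 60000 nM as a limit
Compound 3 (`COc1ccc(-n2c(SCc3ccc(F)cc3)nnc2-c2cc(OC)c(OC)c(OC)c2)cc1`) gives 50700 nM as a true number

In this assay compound 2 stands at > 60000 nM and that is a limit, not a number. Little can be read from this small set, with the limit of > 60000 nM in this assay, at which 2 of the 3 values shown sit, as its main feature.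

Going to compound 4 (`COc1ccc(-n2c(SCC(=O)c3ccc(F)cc3)nnc2-c2cc(OC)c(OC)c(OC)c2)cc1`) puts (4-fluorophenyl)carbonyl in place of phenyl on a saturated chain carbon bound to a sulfur.

The closest measured change is fluoro in place of hydrogen on an aromatic carbon, where an at least 1.1-fold lower number from compound 2 to compound 3 (0.07 log units; that floor lies within the scatter) is the whole result. The related at least 1.1-fold lower number from compound 1 to compound 3 (0.07 log units; that floor lies within the scatter) reads the same way, and a step that the two limits leave unreadable from compound 1 to compound 2 gives no size. Among the measured compounds shown here, no measured compound carries the carbonyl, so its contribution is unknown.

For the measured compounds named here, since compound 3 gives 50700 nM as the only true number, a modest shift toward a lower number is expected, not a large one. The expected move is an at least 2.0-fold lower number from compound 2 to compound 4 (0.30 log units; that floor lies within the scatter) and the result may again be only a limit. For compound 4 the estimated value is 30000 nM with an expected range from 3000 nM to 60000 nM in this estimate.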

Compound 4, half-maximal inhibitory concentration: 42500 nM
For compound 4 the middle estimate is 1.4-fold (0.15 log units) below the measured one; the range from low to high includes it.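

Adding the carbonyl gives the first comparison at this position between two true numbers: in this assay there is a 1.2-fold lower number from compound 3 to compound 4 (0.08 log units; within the scatter), so the two values cannot be told apart, and a carbonyl in the chain on the sulfur makes no readable difference here. Set against the two compounds without a true number, the result reads as an at least 1.4-fold lower number from compound 2 to compound 4 (0.14 log units; that floor lies within the scatter) and as an at least 1.4-fold lower number from compound 1 to compound 4 (0.14 log units; that floor lies within the scatter), and neither floor goes beyond the scatter. These two steps give only floors, because compound 1 and compound 2 each carry a limit and not a number: the limit of > 60000 nM in this assay, at which 2 of the 4 values shown sit.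

Going by these compounds, whether any group at this place can move the value beyond the scatter stays open, for example an amine or a carboxylic acid on the chain. Also open, on these data alone, is how a plain phenylcarbonyl, without the fluoro, would compare with compound 4.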